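The compounds below may be only part of what the source reports. "The series", "measured", "known", "first", "only" and "open" are said of these compounds alone.

Measured compounds:
compound 1 `Cc1cc(SC2CCCCC2)nc(Nc2ccc(C#N)cc2)n1`: >= 192000 nM in an ADME assay on MT4 cells (Homo sapiens) for cytotoxicity, read by MTT assay; a lower number here means that less compound is tolerated, a higher number that more compound is tolerated; the value for compound 1 is a limit, not a number
compound 2 `Cc1cc(OC2CCCCC2)nc(Nc2ccc(C#N)cc2)n1`: 320 nM in this assay

Compound 2 thus holds the only number shown in this assay; the remaining entry is the limit (the limit of >= 192000 nM in this assay, at which 1 of the 2 values shown sits). Going by the values given here, the one measured step, an at least 600-fold lower number from compound 1 to compound 2 (2.77 log units; beyond the scatter), is large and runs toward a lower number with cyclohexyloxy in place of cyclohexylsulfanyl.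

Compound 3 `Cc1cc(NC2CCCCC2)nc(Nc2ccc(C#N)cc2)n1` carries the change (cyclohexylamino in place of cyclohexyloxy on an aromatic carbon). Among the compounds with values here, no measured step exchanges oxygen for nitrogen in this position, so the measured step from compound 1 to compound 2 bears on it only loosely, as a sign that the linking atom of the cyclohexyl group can move the number in this assay by a great deal. A step in either direction beyond the scatter is possible; the expectation is kept broad and centred only a little above the value of compound 2.

Compound 3 is expected to give about 1500 nM in this assay, within 200 nM to 30000 nM. That estimate means a step of a 4.7-fold higher number from compound 2 to compound 3 (0.67 log units; beyond the scatter).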

Compound 3, half-maximal cytotoxic concentration: 340 nM
Compound 3: the middle estimate sits 4.4-fold (0.64 log units) above what was measured; the range from low to high includes it.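

In this assay cyclohexylamino in place of cyclohexyloxy on this aromatic carbon gives a 1.1-fold higher number from compound 2 to compound 3 (0.03 log units; within the scatter) and so leaves the nitrogen and oxygen links indistinguishable here. Cyclohexylamino in place of cyclohexylsulfanyl gives an at least 560-fold lower number from compound 1 to compound 3 (2.75 log units; beyond the scatter) and so shows that the large gap is not confined to the oxygen link; among the three linking atoms, only the sulfur link of compound 1 stands apart. The value of compound 1 is a limit, so this step has a bound but no exact size: the limit of >= 192000 nM in this assay, at which 1 of the 3 values shown sits.

As far as these compounds go, how a methylene link would compare with these three linking atoms stays open. Also open, from the compounds shown here alone, is whether the sulfur link would still stand apart with a phenyl ring or a shorter alkyl chain in place of the cyclohexyl ring.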